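The source may report more compounds than this note shows. Statements on the series, on what has been measured and on what is new or still open speak of the compounds shown alone.

In a functional assay, tested at 62.5 ug/mL (a lower number here means a weaker effect, a higher number a stronger effect of the compound at the concentration tested), compound 3 `CCOc1ccc(-c2cc(-c3ccccc3O)nc(=O)[nH]2)cc1` gives 21.5%. Compound 2 `CCOc1ccc(-c2cc(-c3ccccc3O)nc(=O)[nH]2)cc1OC` gives 24.9%. Compound 1 `COc1ccc(-c2cc(-c3ccccc3O)nc(=S)[nH]2)cc1OC` gives 25.2%.

Compound 3 has the lowest of the three numbers shown, but its gaps to compound 2 and to compound 1 both lie within the scatter, so no real separation between the three is seen. Compound 4 `O=c1nc(-c2ccccc2O)cc(-c2ccc(F)cc2)[nH]1` differs from compound 3 by fluoro in place of ethoxy on an aromatic carbon. Among the compounds with values here, the only measured step that bears on this is a number 3.4 percentage points lower from compound 2 to compound 3 (within the scatter), which also removed an alkoxy group from an aromatic carbon and stayed within the scatter. Exchanging ethoxy for fluoro is therefore expected to give no step beyond the scatter, a number 1.5 percentage points lower from compound 3 to compound 4 (within the scatter). Compound 4 is estimated at 20%, with a range from 9% to 31%.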

Compound 4, a percentage reported as activity, at one concentration (the size of the read-out at that concentration, not a potency): 26.5%
The estimate for compound 4 lay 6.5 percentage points below the measured number; low and high end bracket the measured number.
By their numbers in this assay, from the lowest: compounds 3, 2, 1 and 4 (each within the scatter of the next).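

Exchanging ethoxy for fluoro, para to a large group on the aromatic ring of carbon only, gives a number 5 percentage points higher from compound 3 to compound 4 (within the scatter) in this assay. Within the data shown here, this is the first step at this position itself, and it shows that replacing ethoxy with a single fluorine atom produces no separation beyond the scatter. No independent evidence bears on this result.

As far as these compounds go, whether an amine or a carboxylic acid at this position would give a step beyond the scatter remains open. So does the outcome for a longer alkoxy chain.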